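Trifluoromethyl for phenoxy in a 4H-chromene series

The compounds below may be only part of what the source reports. "The series", "measured", "known", "first", "only" and "open" are said of these compounds alone.

Measured compounds:
- compound 1, `N#CC1=C(N)OC2=C(C(=O)CCC2)C1c1cccc(Br)c1`: 368 ug/mL
- compound 2, `CC1(C)CC(=O)C2=C(C1)OC(N)=C(C#N)C2c1cccc(Oc2ccccc2)c1`: 383 ug/mL

In a functional assay on PANC-1 cells (Homo sapiens) for cytotoxicity, read by MTT assay, with a stated time of 48 h (on this read-out higher numbers stand for weaker inhibition and lower numbers for stronger inhibition), compound 1 gives 368 ug/mL and compound 2 gives 383 ug/mL. Compound 2 carries the higher of the two numbers, but the gap to compound 1 falls within the usual scatter of this assay, so the two values show no real difference between them. Compound 3, `CC1(C)CC(=O)C2=C(C1)OC(N)=C(C#N)C2c1cccc(C(F)(F)F)c1`, is not yet measured. Relative to compound 2 the change is trifluoromethyl in place of phenoxy on an aromatic carbon. Among the measured compounds shown here, no comparable step exists among the measured pairs, so there is nothing to calibrate its size against. Both measured values sit close together at a weak level, and the step from compound 2 to compound 3 is expected to be small, a 1.1-fold lower number from compound 2 to compound 3 (0.04 log units; within the scatter), in no direction beyond the scatter. Compound 3 is therefore estimated at 350 ug/mL, within a range from 150 ug/mL to 800 ug/mL.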

Compound 3, half-maximal inhibitory concentration: 248 ug/mL
Estimate against measurement, compound 3: 1.4-fold (0.15 log units) above, and the stated range covers the measured number.
By their numbers in this assay, from the lowest: compounds 3, 1 and 2 (each within the scatter of the next).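

In this assay, among the compounds shown here, putting trifluoromethyl in place of phenoxy on an aromatic carbon, meta to a large group, gives a 1.5-fold lower number from compound 2 to compound 3 (0.19 log units; within the scatter), and this is the first single-change step that can be read. The whole six-membered aromatic ring of phenoxy and its hydrogen-bond acceptor can therefore leave this position without a shift beyond the scatter, so neither appears to be needed here for the activity seen, weak as it is in both compounds. Nothing measured here bears on why the two groups read alike.

Going by these compounds, it remains open whether an amine or a carboxylic acid on this aromatic carbon would move the number beyond the scatter. On these data alone, it is also open whether any change at this position, or elsewhere on the shared core, can reach a clearly stronger level of inhibition.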